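Aryl variation on the ring amine carbon: estimate for compound 3

The source may hold more compounds than are shown below. What is called first, only, known or untested is meant among the compounds shown, and "the series" means these compounds.

Measured so far in an assay on isolated protein for inhibition of Amine oxidase [flavin-containing] A (Homo sapiens), read by fluorescence, with stated times of 15 min and 20 min; on this read-out higher numbers stand for weaker inhibition and lower numbers for stronger inhibition:
- compound 1, `Cc1ccc(CN2CCC(CCNC(=O)/C=C/c3cc(C(C)(C)C)c(O)c(C(C)(C)C)c3)CC2)cc1`, gives 70100 nM
- compound 2, `CC(C)(C)c1cc(/C=C/C(=O)NCCC2CCN(Cc3ccc(F)cc3F)CC2)cc(C(C)(C)C)c1O`, gives 70600 nM

Going by the values given here, compound 2 holds the highest of the two numbers, and its nearest neighbour is compound 1; the one measured step, a 1.0-fold higher number from compound 1 to compound 2 (0.00 log units; within the scatter), is within the scatter, so no order between the two can be read. The only step shown concerns the aryl group on the saturated chain carbon bound to the amine nitrogen in the ring, and it left the read-out unchanged.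

Compound 3, `CC(C)(C)c1cc(/C=C/C(=O)NCCC2CCN(Cc3ccccc3Cl)CC2)cc(C(C)(C)C)c1O`, differs from compound 2 at the same place: 2-chlorophenyl in place of 2,4-difluorophenyl on a saturated chain carbon bound to an amine nitrogen in a ring. Among the compounds with values here, because the one bearing step a 1.0-fold higher number from compound 1 to compound 2 (0.00 log units; within the scatter) stayed within the scatter, no step beyond the scatter is expected here either. For compound 3 the estimate is 70000 nM, with a range of 35000 nM to 140000 nM, which is expected to amount to a 1.0-fold lower number from compound 2 to compound 3 (0.00 log units; within the scatter).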

Compound 3, half-maximal inhibitory concentration: 72100 nM
Beside the measured number, compound 3's estimate is 1.0-fold (0.01 log units) below it; the range from low to high includes it.
By their numbers in this assay, from the lowest: compounds 1, 2 and 3 (each within the scatter of the next).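

In this assay, 2-chlorophenyl in place of 2,4-difluorophenyl (a 1.0-fold higher number from compound 2 to compound 3 (0.01 log units; within the scatter)) and 2-chlorophenyl in place of 4-methylphenyl (a 1.0-fold higher number from compound 1 to compound 3 (0.01 log units; within the scatter)) both stay within the scatter. On the saturated chain carbon bound to an amine nitrogen in a ring, the flat read-out now extends to a chlorine-bearing aryl group, so the 2-chlorophenyl, 2,4-difluorophenyl and 4-methylphenyl groups cannot be placed in any order. No supporting data bear on why the read-out stays flat at this position.

The compounds shown leave open whether an unsubstituted phenyl, a 4-methoxyphenyl or a cyclohexyl group at this place would give a step beyond the scatter. They also leave open whether a change away from this place, such as a methoxy group in place of the hydroxyl on the shared core, would move the number.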